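This account rests on a few compounds, and the source may have more. Where it says the series, first, only, none or still open, it means among the compounds named here.

Series so far, in a functional assay on SW 1116 cells (Homo sapiens) for antiproliferative activity, read by MTT assay, with a stated time of 24 h; on this read-out higher numbers stand for weaker inhibition and lower numbers for stronger inhibition:
- compound 1 `c1ccc(CSc2nnc(-c3ccc4c(c3)OCCO4)n2-c2ccccc2)cc1`: 7930 nM
- compound 2 `O=[N+]([O-])c1ccc(CSc2nnc(-c3ccc4c(c3)OCCO4)n2-c2ccccc2)cc1`: 13800 nM
- compound 3 `Clc1ccccc1CSc1nnc(-c2ccc3c(c2)OCCO3)n1-c1ccccc1`: not yet measured

For the measured compounds named here, compound 2 lies within the scatter of compound 1, the only other measured compound, so the two cannot be ranked. The next change is 2-chlorophenyl in place of 4-nitrophenyl on a saturated chain carbon bound to a sulfur. Going by the values given here, only one measured step bears on it: a 1.7-fold higher number from compound 1 to compound 2 (0.24 log units; within the scatter), with nitro in place of hydrogen on an aromatic carbon. Among the compounds with values here, no chlorine-bearing compound has been measured yet. With that single step inside the scatter, no change beyond the scatter is expected in this assay, and no firm direction can be assigned. The expected step is a 1.5-fold lower number from compound 2 to compound 3 (0.16 log units; within the scatter). For compound 3 the estimated value is 9500 nM, with an expected range of 3800 nM to 24000 nM.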

Compound 3, half-maximal inhibitory concentration: 9670 nM
Compound 3: middle estimate off by 1.0-fold (0.01 log units), on the low side; the range from low to high includes it.
By their numbers in this assay, from the lowest: compounds 1, 3 and 2 (each within the scatter of the next).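

In this assay, 2-chlorophenyl in place of 4-nitrophenyl on a saturated chain carbon bound to a sulfur gives a step inside the scatter (a 1.4-fold lower number from compound 2 to compound 3 (0.15 log units; within the scatter)), and adding the chlorine alone does the same (a 1.2-fold higher number from compound 1 to compound 3 (0.09 log units; within the scatter)). With chloro now tested alongside nitro, neither of these two ring groups separates from the hydrogen of compound 1, so compounds 1, 2 and 3 cannot be ranked. Nothing measured independently of this read-out bears on the result.

Because 4-nitrophenyl and 2-chlorophenyl differ in both the group and its place on the ring, the two contributions cannot be separated, and 4-chlorophenyl would be the direct comparison. As far as these compounds go, whether an amine or a carboxylic acid on this ring, or a longer chain at this carbon, gives a step beyond the scatter remains open.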